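The source may report more compounds than this note shows. Statements on the series, on what has been measured and on what is new or still open speak of the compounds shown alone.

Among the compounds with values here, compound 1 `COc1ccc2c(=O)c(/C=C/C(=O)Nc3cc(C)ccc3C)coc2c1` is the one member of the series with a number in a functional assay on Huh-7 cells (Homo sapiens) for inhibition, read by MTT assay, with a stated time of 48 h (on this read-out lower numbers stand for stronger inhibition and higher numbers for weaker inhibition), where compound 1 gives 11100 nM. Compound 2 `O=C(/C=C/c1coc2cc(O)ccc2c1=O)NCc1ccc(F)cc1` reaches only the limit of this assay, > 100000 nM. Compound 3 `COc1ccc(NC(=O)/C=C/c2coc3cc(O)ccc3c2=O)cc1` likewise stops at the limit, > 100000 nM. The step that the two limits leave unreadable from compound 2 to compound 3 therefore stays unreadable because the limit of > 100000 nM in this assay, at which 2 of the 3 values shown sit, covers both of its ends. Compound 4 `COc1ccc2c(=O)c(/C=C/C(=O)Nc3ccccc3C)coc2c1` is the next variation: hydrogen in place of methyl on an aromatic carbon. Within the data shown here, no measured step touches this change; the only usable anchor is the single number of compound 1, and the change is small, 2,5-dimethylphenyl to 2-methylphenyl. No step beyond the usual scatter is expected in this assay, so a 1.4-fold higher number from compound 1 to compound 4 (0.13 log units; within the scatter) is expected to fall within it. Compound 4 is estimated at 15000 nM, within 5000 nM to 50000 nM.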

Compound 4, half-maximal inhibitory concentration: 26900 nM
For compound 4 the middle estimate is 1.8-fold (0.25 log units) below the measured one, and the stated range covers the measured number.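

Hydrogen in place of methyl gives a 2.4-fold higher number from compound 1 to compound 4 (0.38 log units; beyond the scatter) in this assay, the first readable step in the series. This position, meta to a large group and para to a methyl group, therefore registers the change, with the 2,5-dimethylphenyl of compound 1 giving the lower number. The finding rests on this single pair, because no other compound shown gives a number to compare: the limit of > 100000 nM in this assay, at which 2 of the 4 values shown sit.

Going by these compounds, what an ethyl group, a chlorine atom or an amine would do at this position stays open. So does the effect of the other methyl group on this ring.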